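Isobutyl to tert-Butyl Ester Change Repeated on a Second Core

A few compounds are considered here, and "the series" means these few. Any claim that something is new, unique, unknown or untested is made for them only; others in the source may bear on it.

Measured compounds, in an assay on membranes from HeLa cells for displacement of a labelled ligand from adenosine receptor A3 (Homo sapiens), read by scintillation counting, with a stated time of 180 min, tested at 1 uM; on this read-out higher numbers stand for more inhibition at the one concentration tested (going by the name of the read-out) and lower numbers for less inhibition:
Compound 1 `CC1=C(C(=O)OCC(C)C)C(c2cccs2)NC(=O)N1`: compound 1 gives 11%
Compound 2 `CC1=C(C(=O)OC(C)(C)C)C(c2cccs2)NC(=O)N1`: compound 2 gives 7%
Compound 3 `CC1=C(C(=O)OCC(C)C)C(c2ccoc2)NC(=S)N1`: compound 3 gives 1%

Compound 2 differs from compound 1 by one change, (tert-butyl in place of isobutyl on an oxygen next to a carbonyl group). This step in this assay was a number 4 percentage points lower from compound 1 to compound 2 (within the scatter), so the two ester groups give readings that cannot be told apart.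

Compound 3 rests on a different core; the difference between the two cores is not broken down here, and its reading sits among the lowest of the three without any of the gaps reaching beyond the scatter.

Compound 4 `CC1=C(C(=O)OC(C)(C)C)C(c2ccoc2)NC(=S)N1` is built from compound 3 by the same change, (tert-butyl in place of isobutyl on an oxygen next to a carbonyl group), at the same place. Among the measured compounds shown here, the only guide is the single earlier pair, where the change barely moved the reading. Compound 4 is therefore expected to stay close to compound 3, with an estimated step of a number 1 percentage points higher from compound 3 to compound 4 (within the scatter) in this assay. The estimate for compound 4 is 2%, expected between -6% and 10%.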

Compound 4, a percentage reported as inhibition, at one concentration (the size of the read-out at that concentration, not a potency): 19%
The estimate for compound 4 lay 17 percentage points below the measured number; measured number outside the range, above it.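

Putting tert-butyl in place of isobutyl on an oxygen next to a carbonyl group gave a number 18 percentage points higher from compound 3 to compound 4 (beyond the scatter) in this assay. On these two pairs, the same change did not give the same result on the two cores, so the step seen on the core of compound 1 was a poor guide to the step on the core of compound 3: the same change on two cores in this assay, a number 4 percentage points lower (within the scatter) from compound 1 to compound 2 and a number 18 percentage points higher (beyond the scatter) from compound 3 to compound 4, 22 percentage points apart, beyond the scatter of two such steps

Among the compounds shown here, with only one pair on each core, this does not show which feature of the cores goes with the different steps or how the change would behave on a third core, and compound 4 at 19% gives inhibition at one concentration, not a potency.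

The compounds shown leave open how other groups on that oxygen, such as a longer chain like hexyl or a ring like cyclohexyl, would read on either core. Also open, going by these compounds, is which part of the core matters, a question that needs a pair of compounds whose cores differ in one place only.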